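Moving one methyl group around the sulfonamide aryl ring

The source may report more compounds than this note shows. Statements on the series, on what has been measured and on what is new or still open speak of the compounds shown alone.

Three compounds have been measured in a functional assay on SK-OV-3 cells (Homo sapiens) for antiproliferative activity, read by sulforhodamine B assay, with a stated time of 48 h; on this read-out lower numbers stand for stronger inhibition and higher numbers for weaker inhibition:

Compound 1 `COc1cc(NS(=O)(=O)c2ccc(N3CCNC3=O)cc2)cc(OC)c1OC` gives 22 nM.
Compound 2 `Cc1cc(C)cc(NS(=O)(=O)c2ccc(N3CCNC3=O)cc2)c1` gives 190 nM.
Compound 3 `O=C1NCCN1c1ccc(S(=O)(=O)Nc2cccc(Cl)c2)cc1` gives 70 nM.

Compound 2 stands highest of the three numbers, meaning the weakest inhibition seen so far. The nearest measured neighbour is a 2.7-fold lower number from compound 2 to compound 3 (0.43 log units; beyond the scatter), a modest step that replaces the whole group on the sulfonamide nitrogen rather than moving part of it. Compound 4 `Cc1ccc(C)c(NS(=O)(=O)c2ccc(N3CCNC3=O)cc2)c1` keeps the same atoms as compound 2 but joins them differently: 2,5-dimethylphenyl in place of 3,5-dimethylphenyl on a sulfonamide nitrogen. Among the measured compounds shown here, no measured pair shows such a rearrangement, so the step from compound 3 does not bear directly on it. The expected step is therefore small, a 1.3-fold lower number from compound 2 to compound 4 (0.10 log units; within the scatter), with no confident direction. Compound 4 is estimated at 150 nM in this assay, with a range from 60 nM to 400 nM.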

Compound 4, half-maximal inhibitory concentration: 72 nM
Compound 4: the middle estimate sits 2.1-fold (0.32 log units) above what was measured; low and high end bracket the measured number.
By their numbers in this assay, from the lowest: compound 1; then compounds 3 and 4 (each within the scatter of the next); then compound 2.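

In this assay there is a 2.6-fold lower number from compound 2 to compound 4 (0.42 log units; beyond the scatter), so rearranging the two methyl groups on the ring at the sulfonamide nitrogen is enough to shift the number, although no atom is added or removed. This position therefore responds to the arrangement of a group, not just to its atoms. Two different groups also give numbers within the scatter of each other, with a 1.0-fold higher number from compound 3 to compound 4 (0.01 log units; within the scatter), so 2,5-dimethylphenyl and 3-chlorophenyl cannot be told apart here.

Nothing available explains the shift. From the compounds shown here alone, whether an amine or a carboxylic acid at this position would be tolerated remains open.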